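A Furan in Place of the Fluorophenyl of Compound 3

The source may hold more compounds than are shown below. What is called first, only, known or untested is meant among the compounds shown, and "the series" means these compounds.

Compound 1 `CC1=CC[C@H](C(C)(C)NC(=S)N/N=C/c2ccccc2)CC1`: 20500 nM in an ADME assay on Vero cells (Chlorocebus sabaeus) for inhibition, read by sulforhodamine B assay, with a stated time of 48 h; on this read-out higher numbers stand for weaker inhibition of growth and lower numbers for stronger inhibition of growth
Compound 2 `CC1=CC[C@H](C(C)(C)NC(=S)N/N=C/c2ccccc2O)CC1`: 3100 nM in this assay
Compound 3 `CC1=CC[C@H](C(C)(C)NC(=S)N/N=C/c2ccc(F)cc2)CC1`: > 100000 nM in this assay, a limit rather than a number

Compound 4 `CC1=CC[C@H](C(C)(C)NC(=S)N/N=C/c2ccco2)CC1` has not yet been measured in this assay. Compound 3 stands at the top of the three: its value in this assay is only a limit, namely (the limit of > 100000 nM in this assay, at which 1 of the 3 values shown sits). The change to compound 4 is furan-2-yl in place of 4-fluorophenyl on a carbon with a double bond to nitrogen. Among the compounds with values here, no measured step involves a furan, but two steps alter the group on that same carbon: an at least 4.8-fold higher number from compound 1 to compound 3 (0.68 log units; beyond the scatter) and an at least 32-fold higher number from compound 2 to compound 3 (1.50 log units; beyond the scatter), both beyond the scatter and the second of them large. Exchanging the group at this carbon therefore shifts the number substantially, and taking the 4-fluorophenyl out is expected to move it back down, as an at least 3.3-fold lower number from compound 3 to compound 4 (0.52 log units; beyond the scatter), although compound 3 carries a limit and the true size of that step is uncertain. Compound 4 is estimated at 30000 nM, within a range from 8000 nM to 120000 nM.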

Compound 4, concentration for 50% growth inhibition: 5100 nM
Estimate against measurement, compound 4: 5.9-fold (0.77 log units) above; measured number below the stated range.
By their numbers in this assay, from the lowest: compounds 2 and 4 (each within the scatter of the next); then compound 1. At a limit, above all of these: compound 3.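

In this assay, furan-2-yl on the carbon with a double bond to nitrogen undoes what the 4-fluorophenyl brought, with an at least 19-fold lower number from compound 3 to compound 4 (1.29 log units; beyond the scatter). Within the data shown here, that step starts from a limit, the one held by compound 3: the limit of > 100000 nM in this assay, at which 1 of the 4 values shown sits. The earlier compounds shown here showed a lower number than the plain phenyl only with a hydroxy on the ring, but a ring without a hydroxy also achieves it, with a 4.0-fold lower number from compound 1 to compound 4 (0.60 log units; beyond the scatter), while a 1.6-fold higher number from compound 2 to compound 4 (0.22 log units; within the scatter), so the two cannot be told apart here.

The compounds shown leave open whether this lower number goes with the ring oxygen or with the smaller ring, a question that a thiophene at this carbon would address. They also leave open how an amine on the furan would read.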